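Nitro in Place of Cyano on a Fused Aromatic Ring

The source may hold more compounds than are shown below. What is called first, only, known or untested is meant among the compounds shown, and "the series" means these compounds.

Of the compounds shown here, three have been measured in a functional assay (aorta) with Rattus norvegicus as the target; a higher number here means that more compound is needed for the effect, a lower number that less compound is needed. Compound 1, `N#Cc1ccc2c(c1)C(N1CCCC1=O)=CC(CF)(CF)O2`, gives 102 nM. Compound 2, `O=C1CCCN1C1=CC(CF)(CF)Oc2ccc([N+](=O)[O-])cc21`, gives 7.76 nM. The change from the first to the second is a single one, (nitro in place of cyano on an aromatic carbon), and it made a 13-fold lower number from compound 1 to compound 2 (1.12 log units; beyond the scatter). Compound 3, `N#Cc1ccc2c(c1)[C@@H](N1CCCCC1=O)[C@H](O)C(CF)(CF)O2`, gives 8.91 nM; its number sits close to that of compound 2, within the scatter, and well apart from that of compound 1. How the core of compound 3 differs from the core of compound 1 is not broken down here.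

Compound 4, `O=C1CCCCN1[C@@H]1c2cc([N+](=O)[O-])ccc2OC(CF)(CF)[C@H]1O`, has not yet been measured. It differs from compound 3 in one place, (nitro in place of cyano on an aromatic carbon). The place is described in the same words as for the change from compound 1 to compound 2, so it is the same change made on a different core.

The expected step from compound 3 to compound 4 in this assay is a 5.9-fold lower number from compound 3 to compound 4 (0.77 log units; beyond the scatter), which rests on the step of a 13-fold lower number from compound 1 to compound 2 (1.12 log units; beyond the scatter) that this change made on the core of compound 1. Since compound 3 already stands where compound 2 does, a somewhat smaller gain is estimated than the earlier one. On that basis compound 4 is expected to give 1.5 nM, with a likely range from 0.5 nM to 5 nM.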

Compound 4, half-maximal effective concentration: 2.75 nM
Beside the measured number, compound 4's estimate is 1.8-fold (0.26 log units) below it; the range from low to high includes it.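

In this assay, nitro in place of cyano lowers the number on the second core as it did on the first, a 3.2-fold lower number from compound 3 to compound 4 (0.51 log units; beyond the scatter), so the direction of the change carries over from the core of compound 1 to the core of compound 3. The size does not carry over, since the two steps are further apart than two such steps would be through scatter alone: the same change on two cores in this assay, a 13-fold lower number (1.12 log units; beyond the scatter) from compound 1 to compound 2 and a 3.2-fold lower number (0.51 log units; beyond the scatter) from compound 3 to compound 4, 4.1-fold (0.61 log units) apart, beyond the scatter of two such steps

This shows that, across these two cores, the change can be relied on for its direction but not for a fixed size, and it does not show what sets the size, as no single change among these compounds separates one core from the other; two cores are also too few to establish a rule for the whole series.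

The compounds shown leave open how a different group on the same aromatic carbon, such as an amine or a carboxylic acid, would compare with nitro and cyano on either core. They also leave open whether, on a third core, the same change would again lower the number in this assay, and by how much.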